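Adding hydroxy to compound 1: an open step

The source may report more compounds than this note shows. Statements on the series, on what has been measured and on what is new or still open speak of the compounds shown alone.

For the measured compounds named here, in a functional assay on RXF 393 cells (Homo sapiens) for inhibition (on this read-out higher numbers stand for weaker inhibition of growth and lower numbers for stronger inhibition of growth), compound 1 (`COc1ccc(-n2cnnc2-c2cc(OC)c(OC)c(OC)c2)cc1`) gives 1580 nM and compound 2 (`COc1cc(-c2nncn2-c2ccc(N(C)C)cc2)cc(OC)c1OC`) gives 1620 nM, so compound 1 stands level with the only other measured compound. Compound 3 (`COc1ccc(-n2cnnc2-c2cc(OC)c(OC)c(OC)c2)cc1O`) carries hydroxy in place of hydrogen on an aromatic carbon, ortho to a methoxy group and meta to a large group: hydroxy in place of hydrogen on an aromatic carbon. Going by the values given here, the one measured step, a 1.0-fold higher number from compound 1 to compound 2 (0.01 log units; within the scatter), replaces methoxy with dimethylamino. It bears only indirectly, since it shows one exchange with no effect beyond the scatter and gives no size for adding hydroxy. Among the compounds with values here, no measured compound carries hydroxy, so the expectation is loose, leaning towards stronger inhibition of growth in this assay. The expected change is a 9.3-fold lower number from compound 1 to compound 3 (0.97 log units; beyond the scatter). For compound 3 the estimated value is 170 nM, with an expected range of 20 nM to 1500 nM.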

Compound 3, concentration for 50% growth inhibition: 309 nM
The estimate for compound 3 lay 1.8-fold (0.26 log units) below the measured number; measured number inside the range.
By their numbers in this assay, from the lowest: compound 3; then compounds 1 and 2 (each within the scatter of the next).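

Hydroxy in place of hydrogen on an aromatic carbon, ortho to a methoxy group and meta to a large group, gives a 5.1-fold lower number from compound 1 to compound 3 (0.71 log units; beyond the scatter) in this assay and so shows that this position can move the read-out. Of the two single changes shown on the core of compound 1, only this one lies beyond the scatter, whereas the exchange of methoxy for dimethylamino gives a 1.0-fold higher number from compound 1 to compound 2 (0.01 log units; within the scatter) and leaves the number within it. No available evidence bears on what lies behind the hydroxy step.

On these data alone, whether the step belongs to hydroxy itself stays open, since an amine, a fluorine or a methoxy group at this same place would be needed to tell. Also open, as far as these compounds go, is whether hydroxy at this place gives a step of similar size on compound 2.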